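A few compounds are considered here, and "the series" means these few. Any claim that something is new, unique, unknown or untested is made for them only; others in the source may bear on it.

In an ADME assay on cells (Homo sapiens) for cytotoxicity, read by polymerase chain reaction, with a stated time of 3 days (a higher number here means that more compound is tolerated, a lower number that less compound is tolerated), compound 3 `CCOCCNc1nc(C)c(-c2nc3ccccc3s2)c(N[C@@H]2C[C@H](CO)[C@@H](O)[C@H]2O)n1` gives 18000 nM, the highest of the three numbers measured; compound 1 `Cc1nc(N)nc(N[C@@H]2C[C@H](CO)[C@@H](O)[C@H]2O)c1-c1nc2ccccc2s1` gives 4000 nM and compound 2 `Cc1nc(NCC2CC2)nc(N[C@@H]2C[C@H](CO)[C@@H](O)[C@H]2O)c1-c1nc2ccccc2s1` gives 8000 nM. Compound 4 `Cc1nc(NCCC(F)(F)F)nc(N[C@@H]2C[C@H](CO)[C@@H](O)[C@H]2O)c1-c1nc2ccccc2s1` differs from compound 3 by trifluoromethyl in place of ethoxy on a saturated chain carbon, two bonds along the chain from a nitrogen on an aromatic ring. Within the data shown here, two measured steps bear on this change: a 4.5-fold higher number from compound 1 to compound 3 (0.65 log units; beyond the scatter) and a 2.3-fold higher number from compound 2 to compound 3 (0.35 log units; beyond the scatter), whereas a 2.0-fold higher number from compound 1 to compound 2 (0.30 log units; within the scatter). The chain of compound 4, like that of compound 2, carries no hydrogen-bond acceptor, so the number is expected to fall back modestly toward that of compound 2, by about a 1.8-fold lower number from compound 3 to compound 4 (0.26 log units; within the scatter). Compound 4 is therefore estimated at 10000 nM in this assay, with a range from 5000 nM to 20000 nM.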

Compound 4, half-maximal cytotoxic concentration: 9000 nM
Estimate against measurement, compound 4: 1.1-fold (0.05 log units) above, and the stated range covers the measured number.
By their numbers in this assay, from the lowest: compounds 1, 2, 4 and 3 (each within the scatter of the next, the first and the last beyond it).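

In this assay, trifluoromethyl in place of ethoxy (a 2.0-fold lower number from compound 3 to compound 4 (0.30 log units; within the scatter)) and 2,2,2-trifluoroethyl in place of cyclopropyl (a 1.1-fold higher number from compound 2 to compound 4 (0.05 log units; within the scatter)) both stay within the scatter, so compound 4 cannot be separated from compound 3 or compound 2. Yet 3,3,3-trifluoropropyl in place of hydrogen on the nitrogen (a 2.3-fold higher number from compound 1 to compound 4 (0.35 log units; beyond the scatter)) lies beyond the scatter, so a group without ethoxy can also separate from compound 1, which cyclopropylmethyl did not do. No evidence is available to explain these steps. As far as these compounds go, whether a longer chain or a terminal amine would move the number beyond the scatter of compound 3 remains open.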